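The source may report more compounds than this note shows. Statements on the series, on what has been measured and on what is new or still open speak of the compounds shown alone.

Compound 1 `CCOC(=O)c1cc(=O)c2cc(CSC(=S)N(C(C)C)C(C)C)ccc2o1` carries diisopropylamino on the thiocarbonyl carbon. In a functional assay on LM7 cells (Homo sapiens) for antiproliferative activity, read by MTT assay, with a stated time of 72 h (on this read-out higher numbers stand for weaker inhibition and lower numbers for stronger inhibition), compound 1 gives > 25000 nM, which is a limit of the assay and not a number. Compound 4 `CCOC(=O)c1cc(=O)c2cc(CSC(=S)N3CCCCC3)ccc2o1` differs from compound 1 in one place: piperidin-1-yl in place of diisopropylamino on a thiocarbonyl carbon. Among the compounds with values here, the only measured step touching the amine on the thiocarbonyl carbon sits on another core: compound 2 `O=c1c(CSC(=S)N2CCCCC2)coc2cc(Cl)ccc12` gives 850 nM in this assay, compound 3 `O=c1c(CSC(=S)N2CCCC2)coc2cc(Cl)ccc12` gives 2600 nM, and a 3.1-fold higher number from compound 2 to compound 3 (0.49 log units; beyond the scatter). That step exchanges one ring for another rather than an open chain for a ring, so it guides only loosely, pointing toward a lower number for the six-membered ring. Compound 1 sits at the limit (the limit of > 25000 nM in this assay, at which 1 of the 3 values shown sits). The expected step in this assay is an at least 2.0-fold lower number from compound 1 to compound 4 (0.31 log units; beyond the scatter). Compound 4 is estimated at 12000 nM, between 3000 nM and 30000 nM.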

Compound 4, half-maximal inhibitory concentration: 16900 nM
Compound 4: the middle estimate sits 1.4-fold (0.15 log units) below what was measured; measured number inside the range.
By their numbers in this assay, from the lowest: compound 2; then compound 3; then compound 4. At a limit, above all of these: compound 1.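

In this assay piperidin-1-yl on the thiocarbonyl carbon gives this core its first measured number, where diisopropylamino gives only a limit. Exchanging the open chain for the ring gives an at least 1.4-fold lower number from compound 1 to compound 4 (0.17 log units; that floor lies within the scatter) and so does not yet establish a real gain. The true size of the step stays unread because compound 1 stands at a limit and not a number: the limit of > 25000 nM in this assay, at which 1 of the 4 values shown sits.

Open on this core is how dimethylamino or morpholin-4-yl on the thiocarbonyl carbon would read. Also open, going by these compounds, is whether pyrrolidin-1-yl again gives a higher number than piperidin-1-yl here.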